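Fluoro for Methyl on a Shared Aryl Core

The source may hold more compounds than are shown below. What is called first, only, known or untested is meant among the compounds shown, and "the series" means these compounds.

Measured compounds:
- compound 1, `Cc1ccc(-c2ccc(F)cc2)n1-c1ccc(-c2nc3ccccc3s2)cc1`, in a functional assay on MCF7 cells (Homo sapiens) for cytotoxicity, read by sulforhodamine B assay, with a stated time of 48 h (a higher number here means a weaker inhibitor of growth, a lower number a stronger inhibitor of growth), compound 1 gives 2620 nM
- compound 2, `Cc1ccc(-c2ccc(C)n2-c2ccc(-c3nc4ccc(F)cc4s3)cc2)cc1`, in this assay compound 2 gives 2150 nM

Compound 2 has the lowest of the two numbers, but its nearest neighbour, compound 1, sits within the scatter of repeated measurements, so the two cannot be told apart on these data. Compound 3, `Cc1ccc(-c2ccc(F)cc2)n1-c1ccc(-c2nc3ccc(F)cc3s2)cc1`, is not yet measured. It differs from compound 2 by fluoro in place of methyl on an aromatic carbon, so that the 4-methylphenyl group of compound 2 becomes a 4-fluorophenyl group in compound 3. Going by the values given here, no step between measured compounds covers this exchange, so there is no measured precedent on this core. Given that both measured compounds fall in the same narrow band, the step from compound 2 to compound 3 in this assay is expected to be a 1.1-fold higher number from compound 2 to compound 3 (0.03 log units; within the scatter), that is, nothing beyond the scatter in either direction. Compound 3 is therefore estimated at 2300 nM, with a range from 1100 nM to 4800 nM.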

Compound 3, concentration for 50% growth inhibition: 1790 nM
The estimate for compound 3 lay 1.3-fold (0.11 log units) above the measured number; the measured number falls inside the stated range.
By their numbers in this assay, from the lowest: compounds 3, 2 and 1 (each within the scatter of the next).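

In this assay, the exchange of 4-methylphenyl for 4-fluorophenyl now has a measured step on this core: a 1.2-fold lower number from compound 2 to compound 3 (0.08 log units; within the scatter), so at this position the two groups cannot be told apart. The other new step gives a 1.5-fold lower number from compound 1 to compound 3 (0.17 log units; within the scatter), so neither change separates the compounds it links. No measurement is available that would explain how close these numbers lie.

From the compounds shown here alone, whether an amine, a carboxylic acid or a longer chain at this position would move the number beyond the scatter remains open. The compounds shown carry only fluoro, methyl or hydrogen at the places that change, so how far the number can move on the shared core also remains open.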